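From Hydroxy to ((Trifluoromethyl)sulfonyl)oxy: What to Expect

The source may report more compounds than this note shows. Statements on the series, on what has been measured and on what is new or still open speak of the compounds shown alone.

Of the compounds shown here, three have so far been measured in an ADME assay on cells (Erythrocyte, Homo sapiens), read by spectrophotometry and hemolysis; a lower number here means a stronger inhibitor, a higher number a weaker inhibitor. Compound 1 `COc1cc2c(c(O)c1C(C)=O)C(=O)CC(C)(C)O2` gives 1.24 ug/mL. Compound 2 `COc1cc(O)c2c(c1C(C)=O)OC(C)(C)C=C2` gives 0.0182 ug/mL, and compound 3 `COc1cc(OC)c2c(c1C(C)=O)OC(C)(C)[C@@H](O)[C@H]2O` gives 0.0094 ug/mL. Among these three numbers compound 2 stands second highest; its nearest neighbour is compound 3, whose value lies within the scatter of repeated measurements, while compound 1, the furthest, lies beyond that scatter with a far higher number.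

The step under consideration leads from compound 2 to compound 4 `COc1cc(OS(=O)(=O)C(F)(F)F)c2c(c1C(C)=O)OC(C)(C)C=C2`, which differs by (trifluoromethyl)sulfonyl in place of hydrogen on an oxygen on an aromatic ring. Cut one bond further out, the change reads hydroxy to ((trifluoromethyl)sulfonyl)oxy. Going by the values given here, no measured pair shows this change, so there is no step to lean on. The author expects only a small step for compound 4, toward a higher number, written as a 2.2-fold higher number from compound 2 to compound 4 (0.34 log units; beyond the scatter), partly because compound 3 gives 0.0094 ug/mL while sharing much of compound 2. Compound 4 is estimated at 0.04 ug/mL, with a range from 0.01 ug/mL to 0.2 ug/mL.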

Compound 4, half-maximal inhibitory concentration: 0.0012 ug/mL
Estimate against measurement, compound 4: 33-fold (1.52 log units) above, outside the stated range (below it).
By their numbers in this assay, from the lowest: compound 4; then compounds 3 and 2 (each within the scatter of the next); then compound 1.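

In this assay, going by these compounds alone, the change from hydroxy to ((trifluoromethyl)sulfonyl)oxy gives a 15-fold lower number from compound 2 to compound 4 (1.18 log units; beyond the scatter), a large step toward a stronger inhibitor and the first step between two measured compounds that differ in one place. It shows that, in this series, the hydrogen on this oxygen on an aromatic ring is not needed for a low number, and that this position accepts a much larger group without any loss in this assay. Nothing measured here explains why the step is so large.

The compounds shown leave open whether this step belongs to the (trifluoromethyl)sulfonyl group itself or would also appear with an acetyl or a methanesulfonyl group on the same oxygen. They also leave open whether the same change on the hydroxy of compound 1 would give a step of similar size.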